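Ring swaps at the aromatic amine position and microsomal clearance

The source may report more compounds than this note shows. Statements on the series, on what has been measured and on what is new or still open speak of the compounds shown alone.

Measured so far:
compound 1, `O=C(Nc1ccnnc1)c1cc(N2CCCC2)ccc1OCc1ccccc1`: 9.8 mL.min-1.g-1
compound 2, `O=C(Nc1ccnnc1)c1cc(N2C[C@H]3COC[C@H]3C2)ccc1OCc1ccccc1`: 4.3 mL.min-1.g-1

In an ADME assay on microsomes from liver (Homo sapiens) for metabolic stability (a lower number here means slower removal, a higher number faster removal of the compound), compound 1 gives 9.8 mL.min-1.g-1, while compound 2 gives 4.3 mL.min-1.g-1. Within the data shown here, the only step in hand is a 2.3-fold lower number from compound 1 to compound 2 (0.36 log units; beyond the scatter). Compound 2 thus stands lowest of the two numbers, with compound 1 as its nearest neighbour, a modest distance away and beyond the scatter.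

Compound 3, `CN1CCN(c2ccc(OCc3ccccc3)c(C(=O)Nc3ccnnc3)c2)CC1`, is the next point at the same aromatic carbon. Its change from compound 2 is a group of 7 heavy atoms (5 carbon, 2 nitrogen; one six-membered non-aromatic ring with 2 hetero atoms) in place of a group of 8 heavy atoms (6 carbon, 1 nitrogen, 1 oxygen; 2 five-membered non-aromatic rings with 1 hetero atom each), on an aromatic carbon.

Among the measured compounds shown here, no measured step covers the 4-methylpiperazin-1-yl group itself; the one step that bears on this position, a 2.3-fold lower number from compound 1 to compound 2 (0.36 log units; beyond the scatter), shows that exchanging the amine ring there moves this assay by a modest amount. With the 4-methylpiperazin-1-yl entering, a step of similar size back toward the number of compound 1 is expected, so compound 3 is expected to give 7 mL.min-1.g-1, within 3.5 mL.min-1.g-1 to 14 mL.min-1.g-1. That estimate means a step of a 1.6-fold higher number from compound 2 to compound 3 (0.21 log units; within the scatter), expected to sit near the edge of the scatter.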

Compound 3, intrinsic clearance in microsomes in the Homo sapiens assay: 1.6 mL.min-1.g-1
Beside the measured number, compound 3's estimate is 4.4-fold (0.64 log units) above it; measured number below the stated range.
By their numbers in the Homo sapiens assay, from the lowest: compound 3; then compound 2; then compound 1.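

In the Homo sapiens assay, the new steps, a 2.7-fold lower number from compound 2 to compound 3 (0.43 log units; beyond the scatter) and a 6.1-fold lower number from compound 1 to compound 3 (0.79 log units; beyond the scatter), show that the amine ring at this aromatic carbon can move the number further than the earlier pair indicated, with 4-methylpiperazin-1-yl giving the lowest number of the three groups. In a physicochemical assay for lipophilicity, at pH 7.4 (a lower number here means a more polar compound, a higher number a more lipophilic compound), compound 2 gives 4.5 and compound 3 gives 3, so this change also moves lipophilicity, and by a large step. The lower clearance of compound 3 relative to compound 2 may therefore be due at least in part to its lower lipophilicity, although one pair cannot settle this: the measured distribution coefficient of compound 2, 4.5, and of compound 3, 3, a number 1.50 log units lower (beyond the scatter).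

The compounds shown leave open whether the clearance follows lipophilicity across the series or depends on the 4-methylpiperazin-1-yl group itself. A morpholine ring or a piperazine ring without the methyl group at the same aromatic carbon would help to separate these two readings.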